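Replacing the difluorophenyl ketone of compound 2 with a benzyl ketone

A few compounds are considered here, and "the series" means these few. Any claim that something is new, unique, unknown or untested is made for them only; others in the source may bear on it.

Measured compounds:
compound 1, `Cc1c(C(=O)c2cnc3ccccc3c2)oc2cc(-c3ccccc3)cc(O)c12`: > 4 ug/mL
compound 2, `Cc1c(C(=O)c2ccc(F)c(F)c2)oc2cc(-c3ccccc3)cc(O)c12`: 0.4 ug/mL
compound 3, `Cc1c(C(=O)c2cccc(C(F)(F)F)c2)oc2cc(-c3ccccc3)cc(O)c12`: > 4 ug/mL

Going by the values given here, in a functional assay on WI-38 VA13 cells (Homo sapiens) for cytotoxicity (a higher number here means that more compound is needed for the effect, a lower number that less compound is needed), compound 2 gives 0.4 ug/mL, the only number among the three values. Compound 1 gives > 4 ug/mL, which is a limit of the assay. Compound 3 gives > 4 ug/mL, again a limit. The assay thus has (the limit of > 4 ug/mL in this assay, at which 2 of the 3 values shown sit). Among the compounds with values here, no two measured compounds differ in one place, so no measured step is available.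

Compound 4, `Cc1c(C(=O)Cc2ccccc2)oc2cc(-c3ccccc3)cc(O)c12`, differs from compound 2 by benzyl in place of 3,4-difluorophenyl on a carbonyl carbon. Two of the three measured compounds sit at the limit, so a weakening step is expected, beyond the scatter, from compound 2 to compound 4: a 5.0-fold higher number from compound 2 to compound 4 (0.70 log units; beyond the scatter). Compound 4 is accordingly expected to give 2 ug/mL in this assay, within a range of 0.6 ug/mL to 4 ug/mL.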

Compound 4, half-maximal effective concentration: > 4 ug/mL
Compound 4 gave a limit, no number (the forecaster's own chance of this, stated with the estimate: 40%); middle value at least 2.0-fold (0.30 log units) from the limit.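

In this assay compound 4 gives > 4 ug/mL, which is a limit of the assay and not a number. Going by these compounds alone, it provides the first step that can be read at this place on a carbonyl carbon: benzyl in place of 3,4-difluorophenyl gives an at least 10-fold higher number from compound 2 to compound 4 (1.00 log units; beyond the scatter), and the true size of the step may be larger. Compound 4 cannot be ordered against compound 1 or compound 3, as all three readings are limits: the limit of > 4 ug/mL in this assay, at which 3 of the 4 values shown sit.

The compounds shown leave open whether a plain phenyl or a monofluorophenyl group on the carbonyl carbon would stay close to compound 2.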